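This account rests on a few compounds, and the source may have more. Where it says the series, first, only, none or still open, it means among the compounds named here.

Working notes on the series, values from a functional assay (strain AB) with Danio rerio as the target, read by microscopy, with a stated time of 1 h; on this read-out lower numbers stand for an effect already at smaller amounts and higher numbers for an effect only at larger amounts of compound
- compound 1 `COCCCN1CCc2c(sc(NC(=O)Nc3ccc(Cl)cc3)c2C(N)=O)C1` gives 2400 nM
- compound 2 `NC(=O)c1c(NC(=O)Nc2ccc(Cl)cc2)sc2c1CCN(CCCNC(=O)CCc1cccnc1)C2` gives 470 nM

Of these two numbers, compound 2 has the lower one. Compound 3 `CCCN1CCc2c(sc(NC(=O)Nc3ccc(Cl)cc3)c2C(N)=O)C1` has not yet been measured and differs from compound 2 thus: hydrogen in place of ((2-(pyridin-3-yl)ethyl)carbonyl)amino on a saturated chain carbon, three bonds along the chain from an amine nitrogen in a ring. Among the measured compounds shown here, the only measured step that bears on this is a 5.1-fold lower number from compound 1 to compound 2 (0.71 log units; beyond the scatter) (modest, beyond the scatter), which introduced the same group in place of methoxy. A reversal of similar size toward a higher number is therefore expected, and the expected step is a 4.3-fold higher number from compound 2 to compound 3 (0.63 log units; beyond the scatter) (in this assay). The estimate for compound 3 is 2000 nM (range 700 nM to 6000 nM).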

Compound 3, half-maximal effective concentration: 3500 nM
Beside the measured number, compound 3's estimate is 1.8-fold (0.24 log units) below it, and the stated range covers the measured number.
By their numbers in this assay, from the lowest: compound 2; then compounds 1 and 3 (each within the scatter of the next).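

In this assay the ((2-(pyridin-3-yl)ethyl)carbonyl)amino group is now compared with hydrogen as well as methoxy at this place, and the loss on removing it (a 7.4-fold higher number from compound 2 to compound 3 (0.87 log units; beyond the scatter)) shows that the lower number of compound 2 goes with that group. Methoxy and hydrogen are not told apart here (a 1.5-fold higher number from compound 1 to compound 3 (0.16 log units; within the scatter)), so the methoxy of compound 1 gives no readable change of its own. Nothing measured on these compounds explains the step.

Which part of the group carries the step stays open. An acetylamino group at the same place, or a phenyl ring in place of the pyridin-3-yl, would separate the amide from the ring.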